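The source may hold more compounds than are shown below. What is called first, only, known or untested is meant among the compounds shown, and "the series" means these compounds.

Of the compounds shown here, three sharing one core have been tested in an assay on isolated protein for inhibition of thyroid hormone receptor alpha (Homo sapiens), read by fluorescence polarization; a higher number here means a weaker inhibitor, a lower number a stronger inhibitor. Compound 1 `CS(=O)(=O)c1ccc(C(=O)NCCC(=O)N2CCCCC2)cc1[N+](=O)[O-]` returns only a limit of the assay, > 60000 nM. Compound 2 `CS(=O)(=O)c1ccc(C(=O)NCCC(=O)N2CCc3ccccc32)cc1[N+](=O)[O-]` likewise returns only a limit, > 60000 nM. Compound 3 `CN(Cc1cccc(F)c1)C(=O)CN(C)C(=O)c1ccc(S(C)(=O)=O)c([N+](=O)[O-])c1` also returns a limit, > 60000 nM. The step that the two limits leave unreadable from compound 1 to compound 2 therefore cannot be read in size or direction, since both of its ends sit at the limit of > 60000 nM in this assay, at which 3 of the 3 values shown sit. Compound 2 thus stands at the limit, as does every other value shown.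

Compound 4 `CS(=O)(=O)c1ccc(C(=O)NCCC(=O)N2CCc3ccccc3C2)cc1[N+](=O)[O-]` differs from compound 2 by 1,2,3,4-tetrahydroisoquinolin-2-yl in place of 2,3-dihydro-1H-indol-1-yl on a carbonyl carbon. Among the measured compounds shown here, the only measured step touching this part of the molecule is a step that the two limits leave unreadable from compound 1 to compound 2, and its size is hidden by the limits, so no measured step gives a direction for the change. With all shown values at the limit, compound 4 is expected to stay close to it as well, and the step is estimated as a step that the limit leaves unreadable from compound 2 to compound 4, nothing beyond the scatter. The estimate for compound 4 in this assay is 80000 nM, expected between 30000 nM and 250000 nM.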

Compound 4, half-maximal inhibitory concentration: > 60000 nM
Compound 4 ended at the assay's limit (the forecaster's own chance of this, stated with the estimate: 85%); the middle value does not contradict the limit.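

Compound 4, like compound 1 and compound 2, gives only a limit of the assay, and the steps linking these three compounds cannot be read in size or direction. The compounds shown leave open which change to the shared core, if any, would give a readable value in this assay rather than a limit.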